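The source may hold more compounds than are shown below. What is called first, only, known or untested is meant among the compounds shown, and "the series" means these compounds.

Compound 1 `C#CC[C@@H]1C[C@H](n2cccc2)C(=O)O1` gives >= 100000 nM in an ADME assay on N2a cells (Mus musculus) for cytotoxicity, read by MTT assay (on this read-out lower numbers stand for stronger inhibition and higher numbers for weaker inhibition), which is a limit of the assay. Compound 2 `C#CC[C@H]1C[C@H](n2cccc2)C(=O)O1` gives > 100000 nM in this assay, also a limit of the assay. Compound 3 `C#CC[C@H]1C[C@H](n2cccc2C(=O)CC)C(=O)O1` gives 40700 nM in this assay.

Compound 1 therefore stands at a limit, not at a number, and the same holds for compound 2. The step that the two limits leave unreadable from compound 1 to compound 2 cannot be read because the limit of > 100000 nM in this assay, at which 1 of the 3 values shown sits, and the limit of >= 100000 nM in this assay, at which 1 of the 3 values shown sits, hide both ends, even though the fact that compounds 1 and 2 differ only in the configuration as drawn makes it the smallest kind of change. Going by the values given here, the step of an at least 2.4-fold lower number from compound 2 to compound 3 (0.39 log units; beyond the scatter) is the one measured change that matters here: an acyl group on the ring lowered the number to a readable value.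

Compound 4 `C#CC[C@@H]1C[C@H](n2cccc2C(=O)C(F)(F)F)C(=O)O1` differs from compound 1 by (trifluoromethyl)carbonyl in place of hydrogen on an aromatic carbon. Among the compounds with values here, that is the same kind of change as the one from compound 2 to compound 3, so a lower number is expected, estimated as an at least 2.5-fold lower number from compound 1 to compound 4 (0.39 log units; beyond the scatter). For compound 4 the expected value in this assay is 40000 nM, estimated to fall between 15000 nM and 100000 nM.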

Compound 4, half-maximal inhibitory concentration: > 100000 nM
Compound 4: only a limit was reported (the forecaster's own chance of this, stated with the estimate: 30%); at least 2.5-fold (0.39 log units) between middle value and limit.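

Compound 1 and compound 4 both stand at a limit of this assay, not at a number, and the step between them cannot be read. The compounds shown leave open how far (trifluoromethyl)carbonyl in place of hydrogen on the aromatic carbon moves the number, or in which direction.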